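A few compounds are considered here, and "the series" means these few. Any claim that something is new, unique, unknown or untested is made for them only; others in the source may bear on it.

Measured so far, in an assay on CHO cells for displacement of a labelled ligand from adenosine receptor A1 (Homo sapiens), read by scintillation counting, with a stated time of 120 min, tested at 10 uM; a lower number here means less inhibition, a higher number more inhibition at the concentration tested (going by the name of the read-out):

Compound 1 `Nc1scc(CN2CCN(c3cccc(Cl)c3Cl)CC2)c1C(=O)c1ccc(Cl)cc1`: 2%
Compound 2 `Nc1scc(CN2CCN(c3cccc(C(F)(F)F)c3)CC2)c1C(=O)c1ccc(Cl)cc1`: 0%
Compound 3 `Nc1scc(CN2CCN(c3cccc(F)c3)CC2)c1C(=O)c1ccc(Cl)cc1`: 1%

Compound 3 stands second highest of the three values, yet its separation from either neighbour is within the scatter: a number 1 percentage points lower from compound 1 to compound 3 (within the scatter) and a number 1 percentage points higher from compound 2 to compound 3 (within the scatter). Compound 4 `Nc1scc(CN2CCN(c3ccc(F)c(F)c3)CC2)c1C(=O)c1ccc(Cl)cc1` differs from compound 3 by fluoro in place of hydrogen on an aromatic carbon. Within the data shown here, the steps that bear on this change are those in which the group on an amine nitrogen in a ring was varied: a number 2 percentage points lower from compound 1 to compound 2 (within the scatter), a number 1 percentage points lower from compound 1 to compound 3 (within the scatter) and a number 1 percentage points higher from compound 2 to compound 3 (within the scatter), each within the scatter. Every such variation left the inhibition essentially unmoved, so no step beyond the scatter is expected for compound 4; the expected step is no change at the digits printed from compound 3 to compound 4 (within the scatter). Compound 4 is therefore estimated at 1%, with a range from -5% to 8%.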

Compound 4, a percentage reported as inhibition, at one concentration (the size of the read-out at that concentration, not a potency): 0%
Compound 4: the middle estimate sits 1 percentage points above what was measured, and the stated range covers the measured number.
By their numbers in this assay, from the lowest: compounds 2, 4, 3 and 1 (each within the scatter of the next).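

In this assay fluoro entering ortho to a fluoro group and para to a large group gives a number 1 percentage points lower from compound 3 to compound 4 (within the scatter) and so extends the flat picture to a second substituent on the same ring. The 3,4-difluorophenyl group also gives no change at the digits printed from compound 2 to compound 4 (within the scatter) and a number 2 percentage points lower from compound 1 to compound 4 (within the scatter) and thus stands with the other three aryl groups, none separated from another beyond the scatter. Nothing at hand explains this flatness.

The compounds shown leave open whether an amine or a carboxylic acid at this place would move the inhibition at all.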